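A few compounds are considered here, and "the series" means these few. Any claim that something is new, unique, unknown or untested is made for them only; others in the source may bear on it.

Measured compounds:
compound 1 `Cc1nc(-c2ccccc2)sc1COc1ccc2c(c1)OCC2CC(=O)O` — 54.8%
compound 2 `Cc1nc(-c2cccc3ccccc23)sc1COc1ccc2c(c1)OCC2CC(=O)O` — 8.53%
compound 3 `Cc1nc(-c2cccc(F)c2)sc1COc1ccc2c(c1)OCC2CC(=O)O` — 56.9%

In a functional assay on CHO cells for agonist activity at Free fatty acid receptor 1 (Homo sapiens), read by FLIPR and calcium flux, tested at 100 nM (a lower number here means a weaker effect, a higher number a stronger effect of the compound at the concentration tested), compound 3 gives the highest of the three numbers, yet its nearest neighbour, compound 1, lies within the scatter of it, and only compound 2 stands far below. The step of a number 2.1 percentage points higher from compound 1 to compound 3 (within the scatter) shows that a fluoro in place of hydrogen changes nothing that can be told from scatter, while a number 46.3 percentage points lower from compound 1 to compound 2 (beyond the scatter) and a number 48.4 percentage points higher from compound 2 to compound 3 (beyond the scatter) show that the naphthalen-1-yl group costs most of the activity.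

The next compound, compound 4 `Cc1nc(-c2ccc(C(F)(F)F)cc2)sc1COc1ccc2c(c1)OCC2CC(=O)O`, carries 4-(trifluoromethyl)phenyl in place of 3-fluorophenyl on an aromatic carbon. For the measured compounds named here, no measured step shows exactly this change. The fluoro of compound 3 was harmless, and the naphthalen-1-yl of compound 2 was harmful; the 4-(trifluoromethyl)phenyl that enters has more heavy atoms than the 3-fluorophenyl that leaves but fewer than the naphthalen-1-yl, so a modest fall, of uncertain size, is expected, a number 16.9 percentage points lower from compound 3 to compound 4 (beyond the scatter). Compound 4 is therefore estimated at 40%, with a range from 15% to 65%.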

Compound 4, a percentage reported as activity, at one concentration (the size of the read-out at that concentration, not a potency): 50.4%
For compound 4 the middle estimate is 10.4 percentage points below the measured one; the range from low to high includes it.
By their numbers in this assay, from the lowest: compound 2; then compounds 4, 1 and 3 (each within the scatter of the next).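

In this assay, the aromatic carbon next to the ring nitrogen and the ring sulfur also carries a 4-(trifluoromethyl)phenyl group without a loss that can be told from scatter: the change from 3-fluorophenyl gives a number 6.5 percentage points lower from compound 3 to compound 4 (within the scatter), and trifluoromethyl in place of hydrogen gives a number 4.4 percentage points lower from compound 1 to compound 4 (within the scatter). Until now, only a single fluoro had been seen to pass unnoticed on this phenyl ring. The change from naphthalen-1-yl gives a number 41.9 percentage points higher from compound 2 to compound 4 (beyond the scatter), so the loss seen with compound 2 does not extend to every group with more heavy atoms than phenyl.

Going by these compounds, whether an amine, a carboxylic acid or a longer chain on the phenyl ring would be accepted as well remains open. The compounds shown come with no measurement that explains this tolerance.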